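The source may hold more compounds than are shown below. What is called first, only, known or untested is meant among the compounds shown, and "the series" means these compounds.

Series notes. In a functional assay on the whole organism for inhibition, with Rattus norvegicus as the target, read by paw edema, at a dose of 100 mg/kg by the oral route (a higher number here means more inhibition at the dose given (going by the name of the read-out), a lower number less inhibition), compound 1 `CNC(=O)c1c(O)c2cccnc2n(-c2ccccc2)c1=O` gives 9.6%; compound 2 `COc1cccc(NC(=O)c2c(O)c3cccnc3n(-c3ccccc3)c2=O)c1` gives 5.7%; compound 3 `O=C(NCc1ccncc1)c1c(O)c2cccnc2n(-c2ccccc2)c1=O` gives 10%. Compound 3 stands highest of the three numbers, but both neighbours lie within the scatter: a number 0.4 percentage points higher from compound 1 to compound 3 (within the scatter) and a number 4.3 percentage points higher from compound 2 to compound 3 (within the scatter), as does a number 3.9 percentage points lower from compound 1 to compound 2 (within the scatter). Every exchange made so far at the amide-type nitrogen has left this assay flat. Compound 4 `Cc1cnccc1NC(=O)c1c(O)c2cccnc2n(-c2ccccc2)c1=O` differs from compound 3 by 3-methylpyridin-4-yl in place of (pyridin-4-yl)methyl on an amide-type nitrogen. Going by the values given here, the steps that bear on this change are the three at the same amide-type nitrogen, none of them beyond the scatter, so no step beyond the scatter is expected in this assay. For compound 4 the expected step is a number 1 percentage points lower from compound 3 to compound 4 (within the scatter). Compound 4 is estimated at 9%, with a range of 0% to 20%.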

Compound 4, a percentage reported as inhibition, in the whole organism at one dose (the size of the read-out at that dose, not a potency): 26.9%
The estimate for compound 4 lay 17.9 percentage points below the measured number, outside the stated range (above it).
By their numbers in this assay, from the lowest: compounds 2, 1 and 3 (each within the scatter of the next); then compound 4.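

The amide-type nitrogen is not flat in this assay: 3-methylpyridin-4-yl gives a number 16.9 percentage points higher from compound 3 to compound 4 (beyond the scatter) and a number 17.3 percentage points higher from compound 1 to compound 4 (beyond the scatter) and also a number 21.2 percentage points higher from compound 2 to compound 4 (beyond the scatter) in the same assay. (Pyridin-4-yl)methyl and 3-methylpyridin-4-yl match in every count computed for them, so those counts do not separate compound 3 from compound 4. No evidence on the cause of this step is available.

The exchange removes the saturated chain carbon and adds a methyl at once, so the share of each remains unresolved. Unsubstituted pyridin-4-yl on the amide-type nitrogen would separate the two.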